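A Nitro Group in Place of Trifluoromethyl

The compounds below may be only part of what the source reports. "The series", "measured", "known", "first", "only" and "open" are said of these compounds alone.

Compound 1 `FC(F)(F)c1ccc(COc2cccc(Nc3ncnc4cc5c(cc34)OCCOCCO5)c2)cc1` carries a trifluoromethyl group on the benzyl ether that hangs from the shared core. In a functional assay on SH-SY5Y cells (Homo sapiens) for antiproliferative activity, read by MTT assay, with a stated time of 72 h (on this read-out lower numbers stand for stronger inhibition and higher numbers for weaker inhibition), compound 1 gives 19300 nM, the lowest of the two numbers shown. Compound 2 `c1ccc(COc2ccc(Nc3ncnc4cc5c(cc34)OCCOCCO5)cc2)cc1`, which has a plain benzyl ether and a different attachment point, gives 39300 nM in this assay, a step beyond the usual scatter. Compound 3 `FC(F)(F)c1ccc(COc2ccccc2Nc2ncnc3cc4c(cc23)OCCOCCOCCO4)cc1`, with a larger ring in the core and yet another attachment point, gives no number in this assay; its entry is a limit, > 100000 nM, (the limit of > 100000 nM in this assay, at which 1 of the 3 values shown sits).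

Compound 4 `O=[N+]([O-])c1ccc(COc2cccc(Nc3ncnc4cc5c(cc34)OCCOCCO5)c2)cc1` differs from compound 1 in one place: nitro in place of trifluoromethyl on an aromatic carbon. For the measured compounds named here, no measured pair in this set shows the effect of this particular swap, so the expectation rests on compound 1 alone. The expected step is small, and the number for compound 4 is estimated to stay close to that of compound 1, with a step of about a 1.1-fold higher number from compound 1 to compound 4 (0.06 log units; within the scatter), within the scatter. Compound 4 is therefore expected to give 22000 nM in this assay, with a range from 8000 nM to 60000 nM.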

Compound 4, half-maximal inhibitory concentration: 36600 nM
Compound 4: the middle estimate sits 1.7-fold (0.22 log units) below what was measured; the measured number falls inside the stated range.
By their numbers in this assay, from the lowest: compounds 1, 4 and 2 (each within the scatter of the next, the first and the last beyond it). At a limit, above all of these: compound 3.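

For the compounds shown here, this is the first pair in the set that differs in one place only, so the group on the benzyl ether can be read on its own while everything else in compound 1 stays fixed. In this assay, putting nitro in place of trifluoromethyl on this aromatic carbon gives a 1.9-fold higher number from compound 1 to compound 4 (0.28 log units; within the scatter) and so the assay does not tell the 4-nitrobenzyl ether from the 4-(trifluoromethyl)benzyl ether, even though only nitro counts hydrogen-bond acceptors and the two groups share no atoms. Nothing measured in this set bears on why these two groups read alike.

The compounds shown leave open whether a group of a different kind on this carbon, such as an amine or a carboxylic acid, would give a step beyond the scatter, since the two groups compared here show only that this one swap does not. They also leave open whether the same swap would read alike with the other attachment points or the larger core ring seen elsewhere in the set.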